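Phenyl-substituted diaminoquinoxaline ethers and thioethers: growth inhibition

This account rests on a few compounds, and the source may have more. Where it says the series, first, only, none or still open, it means among the compounds named here.

The series shares a core carrying a phenyl group and a pendant aryl ether or thioether; all values come from a functional assay on M14 cells (Homo sapiens) for inhibition, read by sulforhodamine B assay, with a stated time of 48 h; a higher number here means a weaker inhibitor of growth, a lower number a stronger inhibitor of growth. Compound 1 `Nc1cc(N)c2nc(-c3ccccc3)c(Oc3ccc(Cl)c(Cl)c3)nc2c1` gives 70800 nM. Compound 2 `COc1cc(CNc2nc3cc(N)cc(N)c3nc2-c2ccccc2)cc(OC)c1OC` gives 18200 nM. Compound 3 `CCOC(=O)[C@H](CCC(=O)O)NC(=O)c1ccc(Oc2nc3cc(N)cc(N)c3nc2-c2ccccc2)cc1` is reported only as a limit, < 100000 nM, being (the limit of < 100000 nM in this assay, at which 1 of the 3 values shown sits). Among the two numbers, compound 1 stands highest, and the gap down to compound 2 is beyond the scatter; no single-change step links them.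

Compound 4 `Nc1cc(N)c2nc(-c3ccccc3)c(Sc3ccc(F)cc3)nc2c1` is not yet measured. It differs from compound 1 by (4-fluorophenyl)sulfanyl in place of 3,4-dichlorophenoxy on an aromatic carbon. Among the measured compounds shown here, no measured pair in this assay shows a change of this kind, so the size of the step rests only on the value of compound 1. The expected step is a 1.4-fold lower number from compound 1 to compound 4 (0.15 log units; within the scatter), toward a somewhat lower number but not clearly beyond the scatter. Compound 4 is estimated at 50000 nM, with a range from 15000 nM to 120000 nM.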

Compound 4, concentration for total growth inhibition: 30900 nM
The estimate for compound 4 lay 1.6-fold (0.21 log units) above the measured number; measured number inside the range.
By their numbers in this assay, from the lowest: compounds 2 and 4 (each within the scatter of the next); then compound 1.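

In this assay, among the compounds shown here, (4-fluorophenyl)sulfanyl in place of 3,4-dichlorophenoxy on this aromatic carbon next to the ring nitrogen gives a 2.3-fold lower number from compound 1 to compound 4 (0.36 log units; beyond the scatter), the first single-change comparison, and shows that the number at this position responds modestly to the pendant group. The change replaces the linking oxygen with sulfur and also alters the substituents on the pendant ring, and the compounds shown do not separate these two parts of the step. Nothing measured on these compounds gives a cause for the step.

Open, as far as these compounds go, is whether a nitrile or a trifluoromethyl on the pendant ring of the thioether would move the number further. Compound 3 remains a limit and cannot be placed in the order: the limit of < 100000 nM in this assay, at which 1 of the 4 values shown sits.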